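The source may report more compounds than this note shows. Statements on the series, on what has been measured and on what is new or still open speak of the compounds shown alone.

Measured in a functional assay on SW982 cells (Homo sapiens) for inhibition, read by MTT assay, with a stated time of 72 h; on this read-out lower numbers stand for stronger inhibition and higher numbers for weaker inhibition:

- compound 1 `COc1cc(OC)c(OC)cc1/C=C/C(=O)c1ccc(F)cc1` gives 32500 nM
- compound 2 `COc1cc(OC)c(OC)cc1/C=C/C(=O)c1ccc([N+](=O)[O-])cc1` gives > 150000 nM (a limit, not a number)

Compound 2 sits at the limit of > 150000 nM in this assay, at which 1 of the 2 values shown sits, so it is known only by that limit. Compound 3 `COc1cc(OC)c(OC)cc1/C=C/C(=O)c1ccc(Br)cc1` differs from compound 2 by bromo in place of nitro on an aromatic carbon. Among the measured compounds shown here, one measured step bears on this change, at the same place on the ring: an at least 4.6-fold higher number from compound 1 to compound 2 (0.66 log units; beyond the scatter). Bromo is not fluoro, so that step is only a rough guide, but taken in reverse it points to a lower number in this assay, by a step beyond the scatter. The estimated change is an at least 4.2-fold lower number from compound 2 to compound 3 (0.63 log units; beyond the scatter). For compound 3 the expected value is 35000 nM, with an estimated range from 14000 nM to 90000 nM.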

Compound 3, half-maximal inhibitory concentration: 38200 nM
The estimate for compound 3 lay 1.1-fold (0.04 log units) below the measured number; the measured number falls inside the stated range.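

In this assay, bromo in place of nitro on the aromatic carbon gives an at least 3.9-fold lower number from compound 2 to compound 3 (0.59 log units; beyond the scatter), so the weak result of compound 2 does not extend to every replacement of fluoro at this place. Bromo in place of fluoro gives a 1.2-fold higher number from compound 1 to compound 3 (0.07 log units; within the scatter), so the two halogens cannot be told apart here, and of the three groups only nitro stands apart. The step from nitro to bromo remains a minimum, since compound 2 is a limit and not a number: the limit of > 150000 nM in this assay, at which 1 of the 3 values shown sits.

The compounds shown leave open whether chloro or plain hydrogen at this place would stay level with fluoro and bromo. They also leave open how an amine, a carboxylic acid or a nitrile on the same carbon would read out, and so whether nitro is an isolated case.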